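The source may report more compounds than this note shows. Statements on the series, on what has been measured and on what is new or still open speak of the compounds shown alone.

Compound 1 `CCOC(=O)c1cc(-c2cc(OC)c(OC)c(OC)c2)c(-c2ccc(OC)c(OCc3ccccc3)c2)s1` carries a benzyl ether; in a functional assay on SGC-7901 cells (Homo sapiens) for antiproliferative activity, read by MTT assay, with a stated time of 72 h (a lower number here means a stronger inhibitor, a higher number a weaker inhibitor), compound 1 gives only a limit, > 100000 nM. Compound 2 `CCOC(=O)c1cc(-c2cc(OC)c(OC)c(OC)c2)c(-c2ccc(OC)c(O)c2)s1` is its partner with hydrogen in place of benzyl, and in this assay compound 2 gives 1580 nM. The change between them is hydrogen in place of benzyl on an oxygen on an aromatic ring and it made an at least 63-fold lower number from compound 1 to compound 2 (1.80 log units; beyond the scatter). The same change is made in a second core: compound 3 `COc1ccc(-c2ccsc2-c2cc(OC)c(OC)c(OC)c2)cc1OCc1ccccc1` goes to compound 4 `COc1ccc(-c2ccsc2-c2cc(OC)c(OC)c(OC)c2)cc1O` by hydrogen in place of benzyl on an oxygen on an aromatic ring. How the core of compound 3 differs from the core of compound 1 is not broken down here. In this assay compound 3 gives only a limit, > 100000 nM. Two of the three measured values sit at the limit of > 100000 nM in this assay, at which 2 of the 3 values shown sit, so the starting point for compound 4 is itself not a number. A large step is expected from compound 3 to compound 4, an at least 20-fold lower number from compound 3 to compound 4 (1.30 log units; beyond the scatter), resting on an at least 63-fold lower number from compound 1 to compound 2 (1.80 log units; beyond the scatter) made by the same change. Compound 4 is accordingly estimated at 5000 nM, within a range of 1000 nM to 60000 nM.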

Compound 4, half-maximal inhibitory concentration: 520 nM
Compound 4: the middle estimate sits 9.6-fold (0.98 log units) above what was measured, outside the stated range (below it).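

In this assay, hydrogen in place of benzyl on the aromatic oxygen gives an at least 190-fold lower number from compound 3 to compound 4 (2.28 log units; beyond the scatter), so the change carries over to a second core in the same direction and remains large: the same change on two cores in this assay, an at least 63-fold lower number (1.80 log units; beyond the scatter) from compound 1 to compound 2 and an at least 190-fold lower number (2.28 log units; beyond the scatter) from compound 3 to compound 4; the limit leaves it open whether they differ Compound 1 and compound 3 each give a limit and not a number, so neither step has a known full size: the limit of > 100000 nM in this assay, at which 2 of the 4 values shown sit. Two cores show that the change carried over here, but they give no general rule for the series and no ranking of the cores by step size.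

The compounds shown leave open how another group on that oxygen, such as methyl or acetyl, would compare with hydroxy. Also open, on these data alone, is how an amine in place of the hydroxy would read out.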